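The compounds below may be only part of what the source reports. "The series", "measured", "known", "first", "only" and "open" are said of these compounds alone.

Series notes, cytotoxicity on the glioma cells.

Three compounds have numbers in a functional assay on C6 cells (Rattus norvegicus) for cytotoxicity, read by MTT assay, with a stated time of 24 h, tested at 200 ug/mL; on this read-out higher numbers stand for a weaker effect at the one concentration tested and lower numbers for a stronger effect. Compound 1 `O=C(CSc1nnnn1-c1ccccc1)N/N=c1/scc(-c2ccc(Br)cc2)n1-c1ccccc1` gives 20.4%. Among the measured compounds shown here, compound 2 `O=C(CSc1nnnn1-c1ccccc1)N/N=c1/scc(-c2ccc(F)cc2)n1-c1ccccc1` gives 30.6% in this assay; the one measured step, a number 10.2 percentage points higher from compound 1 to compound 2 (beyond the scatter), is the only change so far that reaches beyond the scatter. Compound 3 `Cn1nnnc1SCC(=O)N/N=c1/scc(-c2ccc(C#N)cc2)n1-c1ccccc1` gives 28.6% in this assay, the second highest of the three numbers; its nearest neighbour is compound 2, and compound 1 also lies within the scatter of it, so no order among compounds 2 and 3 or between 3 and 1 can be read from these numbers.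

Compound 4 `N#Cc1ccc(-c2cs/c(=N/NC(=O)CSc3nnnn3-c3ccccc3)n2-c2ccccc2)cc1` is not yet measured. It differs from compound 3 by phenyl in place of methyl on an aromatic nitrogen, that is, 1-methyl-1H-tetrazol-5-yl becomes 1-phenyl-1H-tetrazol-5-yl. For the measured compounds named here, no measured step covers this change directly. The step of a number 10.2 percentage points higher from compound 1 to compound 2 (beyond the scatter) concerns the halogen on the aryl ring, a different position, and bears on it only indirectly. Compounds 1 and 2 already carry the phenyl-bearing tetrazole and their numbers sit within the scatter of compound 3, which gives no sign of a sizeable effect of this group. The expected step of a number 1.6 percentage points lower from compound 3 to compound 4 (within the scatter) is therefore none beyond the scatter. Compound 4 is estimated at 27%, with a range from 15% to 40%.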

Compound 4, a percentage reported as activity, at one concentration (the size of the read-out at that concentration, not a potency): 54%
Compound 4: the middle estimate sits 27 percentage points below what was measured; measured number above the stated range.
By their numbers in this assay, from the lowest: compounds 1, 3 and 2 (each within the scatter of the next, the first and the last beyond it); then compound 4.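

In this assay, the exchange of 1-methyl-1H-tetrazol-5-yl for 1-phenyl-1H-tetrazol-5-yl is not a neutral change when the aryl ring carries cyano: the step is a number 25.4 percentage points higher from compound 3 to compound 4 (beyond the scatter), meaning a weaker effect at the one concentration tested. The phenyl on the aromatic nitrogen does not fix the level by itself, as the aryl substituent still moves the number strongly with this tetrazole in place, giving a number 23.4 percentage points higher from compound 2 to compound 4 (beyond the scatter) and a number 33.6 percentage points higher from compound 1 to compound 4 (beyond the scatter). The size of the phenyl step therefore applies so far only to the cyano-bearing compounds, and no available evidence gives a reason for any of these steps.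

Going by these compounds, it remains open whether methyl in place of phenyl on the same nitrogen would produce a step of similar size in the bromo and fluoro compounds, which would show whether the two positions act independently or depend on each other. Also open, on these data alone, is how a benzyl or pyridyl group on the tetrazole, or an amine or a carboxylic acid on the aryl ring, would read in this assay.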